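A few compounds are considered here, and "the series" means these few. Any claim that something is new, unique, unknown or untested is made for them only; others in the source may bear on it.

Both measurements come from an ADME assay on MRC5 cells (Homo sapiens) for cytotoxicity, read by fluorescence and resazurin assay, with a stated time of 3 days (on this read-out higher numbers stand for weaker inhibition and lower numbers for stronger inhibition), which reports how much of each compound is needed to inhibit the growth of human lung cells. Compound 1, with the structure `Cc1cn(C2CCN(Cc3cccc(OC4CCCCC4)c3)CC2)c(=O)[nH]c1=O`, gives 23600 nM in this assay. Compound 2, with the structure `Cc1cn(C2CCN(Cc3ccnc(Oc4ccccc4)c3)CC2)c(=O)[nH]c1=O`, reached only the limit of this assay, > 64000 nM, so no number is known for it. Compound 1 therefore holds the only measured value here, while the other result sits at a limit, as shown by the limit of > 64000 nM in this assay, at which 1 of the 2 values shown sits. Within the data shown here, no pair of measured compounds differs in a single place, so no measured step is available.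

Compound 3, with the structure `Cc1cn(C2CCN(Cc3cccc(Oc4ccccn4)c3)CC2)c(=O)[nH]c1=O`, has not yet been tested. It differs from compound 1 by pyridin-2-yl in place of cyclohexyl on an oxygen on an aromatic ring. Among the measured compounds shown here, with no measured step to lean on, the expectation for compound 3 rests only on compound 1 at 23600 nM and on the fact that compound 2 gave no number. The step from compound 1 to compound 3 in this assay is estimated at a 1.9-fold higher number from compound 1 to compound 3 (0.28 log units; within the scatter), toward weaker inhibition. Compound 3 is expected to give about 45000 nM in this assay, within a range from 18000 nM to 110000 nM.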

Compound 3, half-maximal inhibitory concentration: > 64000 nM
Compound 3: a limit, no number; the forecaster's own chance of this, stated with the estimate: 40%; at least 1.4-fold (0.15 log units) between middle value and limit.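

Among these compounds, putting pyridin-2-yl in place of cyclohexyl on an oxygen on an aromatic ring gives the first measured step in this assay: an at least 2.7-fold higher number from compound 1 to compound 3 (0.43 log units; beyond the scatter). This shows that the change at this one place moves the read-out beyond the usual scatter, toward weaker inhibition of the cells, which neither earlier compound could show on its own. Among the compounds shown here, compound 3 sits at a limit, so the step has a lower bound but no full size, and compound 1 remains the only compound with an actual number: the limit of > 64000 nM in this assay, at which 2 of the 3 values shown sit.

The data leave open whether the step follows from the ring nitrogen or from the aromatic ring as a whole, and a phenyl group on this same oxygen of the core of compound 1 would help to separate the two. Also open, as far as these compounds go, is how the read-out would respond to other groups at this place, such as a cyclohexyl ring carrying an amine or a carboxylic acid, or a longer chain.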